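Swapping fluorine for methyl on a small ring

The source may hold more compounds than are shown below. What is called first, only, known or untested is meant among the compounds shown, and "the series" means these compounds.

Three compounds share one core. Compound 1 `CCC(=O)N1CC2CC(C1)N2` carries an ethyl group on the carbonyl carbon, and in an assay on SH-EP1 cells for agonist activity at Neuronal acetylcholine receptor; alpha4/beta2 (Homo sapiens), read by FLIPR and calcium flux (a higher number here means that more compound is needed for the effect, a lower number that less compound is needed), compound 1 gives 5900 nM. Compound 2 `O=C([C@H]1C[C@@H]1F)N1CC2CC(C1)N2` and compound 3 `O=C([C@@H]1C[C@H]1F)N1CC2CC(C1)N2` carry a 2-fluorocyclopropyl group there instead, drawn as two different stereochemical forms; compound 2 gives 2800 nM and compound 3 gives 870 nM. Compound 3 thus stands at the lowest number of the three. The steps were a 2.1-fold lower number from compound 1 to compound 2 (0.32 log units; beyond the scatter), a 6.8-fold lower number from compound 1 to compound 3 (0.83 log units; beyond the scatter) and a 3.2-fold lower number from compound 2 to compound 3 (0.51 log units; beyond the scatter), the last resting on (the fact that one of compounds 2 and 3 is drawn with a defined configuration and the other without, at the place where they differ).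

Compound 4 `C[C@H]1C[C@H]1C(=O)N1CC2CC(C1)N2` is not yet measured. Relative to compound 3 it changes as follows: 2-methylcyclopropyl in place of 2-fluorocyclopropyl on a carbonyl carbon. Within the data shown here, none of the measured steps exchanges fluorine for methyl on the ring, so they set only a loose frame: the whole span from compound 1 to compound 3 is moderate. The step from compound 3 to compound 4 is therefore expected to be small to modest, most likely towards a higher number, a 1.7-fold higher number from compound 3 to compound 4 (0.24 log units; within the scatter). Compound 4 is estimated at 1500 nM, within 400 nM to 6000 nM.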

Compound 4, half-maximal effective concentration: 5800 nM
The estimate for compound 4 lay 3.9-fold (0.59 log units) below the measured number, and the stated range covers the measured number.
By their numbers in this assay, from the lowest: compound 3; then compound 2; then compounds 4 and 1 (each within the scatter of the next).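

Exchanging 2-fluorocyclopropyl for 2-methylcyclopropyl on the carbonyl carbon gives, in this assay, both a 6.7-fold higher number from compound 3 to compound 4 (0.82 log units; beyond the scatter) and a 2.1-fold higher number from compound 2 to compound 4 (0.32 log units; beyond the scatter). Set against ethyl, 2-methylcyclopropyl shows a 1.0-fold lower number from compound 1 to compound 4 (0.01 log units; within the scatter) and leaves compound 1 and compound 4 indistinguishable. The earlier compounds shown here could not separate the three-membered ring from its fluorine, whereas compound 4 shows that this ring carrying methyl does not reach the lower numbers of compound 2 and compound 3, so at this position the fluorine-bearing ring and the methyl-bearing ring are not interchangeable.

Still open, from the compounds shown here alone, is how other groups would behave at this place, such as an amine or a longer chain, and how other stereochemical forms of 2-methylcyclopropyl would compare. Nothing given here explains the difference between the fluorine-bearing and methyl-bearing rings.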